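This account rests on a few compounds, and the source may have more. Where it says the series, first, only, none or still open, it means among the compounds named here.

In a functional assay on HCC 2998 cells (Homo sapiens) for inhibition, with a stated time of 48 h (on this read-out higher numbers stand for weaker inhibition of growth and lower numbers for stronger inhibition of growth), compound 1 `COc1ccccc1/C=C/C(=O)c1c(O)cc2occc2c1OC` reports only a limit, > 100000 nM. Two compounds give actual numbers: compound 2 `COc1c(C(=O)/C=C/c2ccc(Cl)cc2)c(O)c(Br)c2occc12` gives 2500 nM and compound 3 `C=CCc1c(O)c(C(=O)/C=C/c2ccccc2)c(OC)c2ccoc12` gives 1730 nM. These two values lie within the usual scatter of each other, so compound 3 stands level with compound 2. Compound 4 `C=CCc1c(O)c(C(=O)/C=C/c2ccc(Cl)cc2)c(OC)c2ccoc12` differs from compound 3 in one place: chloro in place of hydrogen on an aromatic carbon, with chloro in place of hydrogen on an aromatic carbon. Among the measured compounds shown here, no measured pair shows this change alone. Compound 2 also carries a 4-chlorophenyl group and gives 2500 nM, so no large shift is expected. The expected step, a 1.2-fold lower number from compound 3 to compound 4 (0.06 log units; within the scatter), should stay within the scatter. Compound 4 is estimated at 1500 nM, with an expected range of 600 nM to 4000 nM.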

Compound 4, concentration for 50% growth inhibition: 1790 nM
Estimate against measurement, compound 4: 1.2-fold (0.08 log units) below, and the stated range covers the measured number.
By their numbers in this assay, from the lowest: compounds 3, 4 and 2 (each within the scatter of the next). At a limit, above all of these: compound 1.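

In this assay the change from phenyl to 4-chlorophenyl can now be read directly as a 1.0-fold higher number from compound 3 to compound 4 (0.01 log units; within the scatter) and so gives no real difference at this position, para to a large group. Allyl in place of bromo on an aromatic carbon, a second swap the earlier compounds could not show, gives a 1.4-fold lower number from compound 2 to compound 4 (0.15 log units; within the scatter) and likewise no real difference. On these data alone, whether an amine or a carboxylic acid at the chloro position, or a longer chain in place of allyl, would hold the number stays open. No measurement shown here accounts for these results.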